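The source may hold more compounds than are shown below. What is called first, only, known or untested is meant among the compounds shown, and "the series" means these compounds.

Within the data shown here, compound 1 `COc1ccc2c(=O)c(/C=C/C(=O)Nc3ccccc3)coc2c1` is the only member of the series with a plain number in a functional assay (QGY7701 cells, Homo sapiens) for inhibition, read by MTT assay, with a stated time of 48 h; a higher number here means a weaker inhibitor, a lower number a stronger inhibitor: compound 1 gives 14000 nM. Compound 2 `COc1ccc2c(=O)c(/C=C/C(=O)Nc3ccc(Cl)cc3)coc2c1` carries chloro in place of hydrogen on an aromatic carbon; in this assay compound 2 is reported only as the limit > 100000 nM. Compound 3 `CCOc1ccc(NC(=O)/C=C/c2coc3cc(OC)ccc3c2=O)cc1` carries ethoxy in place of hydrogen on an aromatic carbon; in this assay compound 3 likewise reaches only the limit > 100000 nM. The steps of an at least 7.1-fold higher number from compound 1 to compound 2 (0.85 log units; beyond the scatter) and an at least 7.1-fold higher number from compound 1 to compound 3 (0.85 log units; beyond the scatter) both read as a weakening, while a step that the two limits leave unreadable from compound 2 to compound 3. The limit itself, (the limit of > 100000 nM in this assay, at which 2 of the 3 values shown sit), sets the ceiling of what can be read in this set.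

Compound 4 `COc1cccc(NC(=O)/C=C/c2coc3cc(OC)ccc3c2=O)c1` differs from compound 1 by methoxy in place of hydrogen on an aromatic carbon. Both substitutions on the same ring measured so far, chloro and ethoxy, carried the number past the limit, and methoxy is the nearer relative of ethoxy; a weakening of comparable size is therefore expected, a 5.7-fold higher number from compound 1 to compound 4 (0.76 log units; beyond the scatter). Compound 4 is estimated at 80000 nM, with a range of 20000 nM to 200000 nM, and a substantial chance that only a limit is reported.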

Compound 4, half-maximal inhibitory concentration: 39100 nM
Compound 4: the middle estimate sits 2.0-fold (0.31 log units) above what was measured; the measured number falls inside the stated range.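

In this assay, among these compounds, methoxy on an aromatic carbon meta to a large group gives the first plain number for a substituted phenyl, and that number still marks a loss: a 2.8-fold higher number from compound 1 to compound 4 (0.45 log units; beyond the scatter). A substituent on this ring therefore does not always carry the number to the limit, since the 3-methoxyphenyl stays readable, with an at least 2.5-fold lower number from compound 3 to compound 4 (0.40 log units; beyond the scatter) and an at least 2.5-fold lower number from compound 2 to compound 4 (0.40 log units; beyond the scatter). Those two steps give only a minimum size, and the step between compound 2 and compound 3 cannot be read: the limit of > 100000 nM in this assay, at which 2 of the 4 values shown sit.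

Compound 3 differs from compound 4 in both the group and its place on the ring, so the two changes stay unseparated. On these data alone, whether a hydroxyl, an amine or a carboxylic acid in the place of the methoxy would match or better compound 1 remains open.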